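A few compounds are considered here, and "the series" means these few. Any claim that something is new, unique, unknown or untested is made for them only; others in the source may bear on it.

Among the measured compounds shown here, in a functional assay on A549 cells (Homo sapiens) for antiproliferative activity, read by MTT assay, with a stated time of 48 h (on this read-out lower numbers stand for stronger inhibition of growth and higher numbers for weaker inhibition of growth), only two compounds with this core have numbers so far. Compound 1 `Cc1ccc(OCCCCN(Cc2ccc(C(=O)NO)cc2)c2ncc(-c3ccc(C)cc3)s2)cc1` gives 8630 nM and compound 2 `Cc1ccc(-c2cnc(N(Cc3ccc(C(=O)NO)cc3)C(C)C)s2)cc1` gives 3830 nM as the lower of the two. Compound 3 `Cc1ccc(-c2cnc(N(CCCOc3ccccc3)Cc3ccc(C(=O)NO)cc3)s2)cc1` keeps the core of compound 2 but carries 3-phenoxypropyl in place of isopropyl on a nitrogen on an aromatic ring. For the measured compounds named here, one measured step bears on this change. It is modest (a 2.3-fold lower number from compound 1 to compound 2 (0.35 log units; beyond the scatter)) and came with isopropyl replacing 4-(4-methylphenoxy)butyl at that same place. Going by the values given here, the new group is closer in kind to the one in compound 1, so a small move to a higher number is expected in this assay, no larger than that step. One step is thin evidence, so the range stays wide. The expected change is small (a 1.7-fold higher number from compound 2 to compound 3 (0.23 log units; within the scatter)). For compound 3 the estimated value is 6500 nM (expected range 2800 nM to 14000 nM).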

Compound 3, concentration for 50% growth inhibition: 2530 nM
Beside the measured number, compound 3's estimate is 2.6-fold (0.41 log units) above it; measured number outside the range, below it.
By their numbers in this assay, from the lowest: compounds 3 and 2 (each within the scatter of the next); then compound 1.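

In this assay, the step from the small isopropyl group to the much larger 3-phenoxypropyl group is a 1.5-fold lower number from compound 2 to compound 3 (0.18 log units; within the scatter), so this assay does not separate the two groups at this nitrogen. Compound 1 had suggested that a long phenoxy-bearing chain here goes with a higher number, but compound 3 carries such a chain and still shows a 3.4-fold lower number from compound 1 to compound 3 (0.53 log units; beyond the scatter), so the presence of a chain of this kind does not by itself decide the outcome. No measurement shown gives a reason for these results.

The step from compound 1 to compound 3 shortens the chain and removes the ring methyl together, which leaves the contribution of each unresolved. Also open, from the compounds shown here alone, is how this position would respond to a 3-phenylpropyl group, which lacks the ether oxygen, or to a chain ending in an amine.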